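A few compounds are considered here, and "the series" means these few. Any claim that something is new, unique, unknown or untested is made for them only; others in the source may bear on it.

Measured compounds:
compound 1 `Oc1nnc(-c2cccnc2)c2ccccc12` — 10200 nM
compound 2 `CC(=O)Cn1nc(-c2cccnc2)c2ccccc2c1=O` — 40700 nM

In a functional assay (trachea) with Cavia porcellus as the target (on this read-out lower numbers stand for stronger inhibition and higher numbers for weaker inhibition), compound 2 gives 40700 nM, the highest of the two numbers recorded; compound 1 sits at a lower number, a gap beyond the scatter. The next compound, compound 3 `NCCn1nc(-c2cccnc2)c2ccccc2c1=O`, carries the change (aminomethyl in place of acetyl on a saturated chain carbon bound to an aromatic nitrogen); cut one bond further out, the same difference reads 2-oxopropyl to 2-aminoethyl. No measured pair shows this change, so the size of the step rests on nothing shown. A small step toward a lower number, or none beyond the scatter, is expected, a 1.6-fold lower number from compound 2 to compound 3 (0.21 log units; within the scatter). Compound 3 is estimated at 25000 nM, with a range from 8000 nM to 80000 nM.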

Compound 3, half-maximal inhibitory concentration: > 100000 nM
Compound 3: a limit, no number; the forecaster's own chance of this, stated with the estimate: 15%; at least 4.0-fold (0.60 log units) between middle value and limit.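

In this assay, the group on a saturated chain carbon bound to an aromatic nitrogen clearly affects the read-out: aminomethyl in place of acetyl gives an at least 2.4-fold higher number from compound 2 to compound 3 (0.39 log units; beyond the scatter). The size of this step stays open at its upper end, since compound 3 gives a limit and not a number: the limit of > 100000 nM in this assay, at which 1 of the 3 values shown sits.

The compounds shown leave open whether the weaker read-out follows from the terminal amine or from the loss of the acetyl. A dimethylamino group, a carboxylic acid or a longer chain at this place would help separate the two.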